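Methoxy for Fluoro: Cytotoxicity Expected to Stay Low

The compounds below may be only part of what the source reports. "The series", "measured", "known", "first", "only" and "open" are said of these compounds alone.

In an ADME assay on NIH3T3 cells (Mus musculus) for cytotoxicity, read by CCK-8 assay, with a stated time of 24 h (a higher number here means a weaker inhibitor, a lower number a stronger inhibitor), compound 3 `C/C(=C\c1cc(-c2ccc(F)cc2)cs1)C(N)=O` gives > 50000 nM, which is a limit of the assay and not a measured number. Compound 1 `C/C(=C\c1cc(-c2ccc(F)cc2)co1)C(N)=O` gives > 50000 nM in this assay, also a limit. Compound 2 `C/C(=C\c1cc(-c2ccc(C)nc2)co1)C(N)=O` gives > 50000 nM in this assay, again a limit. Within the data shown here, all three measured compounds therefore stand at the limit of > 50000 nM in this assay, at which 3 of the 3 values shown sit, so no step between measured compounds can be read from these numbers.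

Compound 4 `COc1ccc(-c2csc(/C=C(\C)C(N)=O)c2)cc1` differs from compound 3 by methoxy in place of fluoro on an aromatic carbon. With every measured value at the limit, no step beyond the scatter is expected in this assay. Compound 4 is estimated at 60000 nM, within 30000 nM to 150000 nM. The implied step that the limit leaves unreadable from compound 3 to compound 4 is expected to lie within the scatter, most likely as another limit.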

Compound 4, half-maximal inhibitory concentration: > 50000 nM
Compound 4: only a limit was reported; the forecaster's own chance of this, stated with the estimate: 85%; the middle value lies beyond the limit too.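

Among these compounds, no step from compound 3 to compound 4 can be read, as both compounds give only a limit in this assay: the limit of > 50000 nM in this assay, at which 4 of the 4 values shown sit. The compounds shown leave open which structural changes, if any, would bring a measurable half-maximal inhibitory concentration.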